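Methyl addition on the aryl ketone in two cores

A few compounds are considered here, and "the series" means these few. Any claim that something is new, unique, unknown or untested is made for them only; others in the source may bear on it.

Compound 1 `Cc1ccc(C(=O)CCc2nnc(-c3ccccc3)o2)cc1` gives 33.3% in a functional assay on the whole organism (strain Wistar) for inhibition, with Rattus norvegicus as the target, with stated times of 30 min and 2 h, at a dose of 20 mg/kg by the oral route; a higher number here means more inhibition at the dose given (going by the name of the read-out), a lower number less inhibition. Compound 2 `Cc1ccc(C(=O)CCc2nnc(-c3ccccc3)o2)c(C)c1` carries one change, (methyl in place of hydrogen on an aromatic carbon), and in this assay compound 2 gives 36%; the step is a number 2.7 percentage points higher from compound 1 to compound 2 (within the scatter). Compound 3 `Cc1ccc(C(=O)CCc2nnc(Cc3ccccc3)o2)cc1` differs from compound 1 in the core, (benzyl in place of phenyl on an aromatic carbon), and in this assay compound 3 gives 24.7%; the step is a number 8.6 percentage points lower from compound 1 to compound 3 (within the scatter). Compound 4 `Cc1ccc(C(=O)CCc2nnc(Cc3ccccc3)o2)c(C)c1` is not yet measured; it differs from compound 3 by methyl in place of hydrogen on an aromatic carbon, the same change as that from compound 1 to compound 2, at a place described in the same words. The step from compound 3 to compound 4 is expected to be a number 2.3 percentage points higher from compound 3 to compound 4 (within the scatter), matching the earlier one, which rests on compound 1 and compound 2 showing a number 2.7 percentage points higher from compound 1 to compound 2 (within the scatter). For compound 4 the expected value is 27%, estimated between 17% and 37%.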

Compound 4, a percentage reported as inhibition, in the whole organism at one dose (the size of the read-out at that dose, not a potency): 25.3%
For compound 4 the middle estimate is 1.7 percentage points above the measured one, within the range that was stated.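

In this assay the methyl change carries over to the core of compound 3, with a number 0.6 percentage points higher from compound 3 to compound 4 (within the scatter), and the two cores do not differ in this step: the same change on two cores in this assay, a number 2.7 percentage points higher (within the scatter) from compound 1 to compound 2 and a number 0.6 percentage points higher (within the scatter) from compound 3 to compound 4, 2.1 percentage points apart, within the scatter of two such steps. The change from phenyl to benzyl, read on the dimethyl pair as a number 10.7 percentage points lower from compound 2 to compound 4 (beyond the scatter), likewise reads the same on both: the same change on two cores in this assay, a number 8.6 percentage points lower (within the scatter) from compound 1 to compound 3 and a number 10.7 percentage points lower (beyond the scatter) from compound 2 to compound 4, 2.1 percentage points apart, within the scatter of two such steps. The methyl step stays within the scatter on both cores, so no effect of the added methyl is shown, and the agreement covers only these four compounds at one dose.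

Left open is how an amine or a carboxylic acid would read in place of the added methyl. On these data alone, a longer chain in place of benzyl also remains open.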